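This account rests on a few compounds, and the source may have more. Where it says the series, first, only, none or still open, it means among the compounds named here.

Measured compounds:
- Compound 1 `N[C@H]1CC[C@H](Nc2c(C(=O)NCc3ccc(Oc4ccccc4)cc3)nc(Br)c3cccnc23)CC1` gives 4000 nM in a functional assay on MDA-MB-435 cells (Homo sapiens) for cytotoxicity, read by MTT assay, with a stated time of 72 h; a lower number here means a stronger inhibitor, a higher number a weaker inhibitor.
- Compound 2 `COc1ccc(CNC(=O)c2nc(Br)c3cccnc3c2N[C@H]2CC[C@H](N)CC2)cc1` gives 5000 nM in this assay.
- Compound 3 `N[C@H]1CC[C@H](Nc2c(C(=O)NC3CCCCC3)nc(Br)c3cccnc23)CC1` gives > 10000 nM in this assay, which is a limit of the assay and not a number.

Compound 3 stands at the limit of > 10000 nM in this assay, at which 1 of the 3 values shown sits; its entry marks only the edge of what the assay reports. Two measured steps frame the change in hand. The step of a 1.3-fold higher number from compound 1 to compound 2 (0.10 log units; within the scatter) left the number where it was. The step of an at least 2.0-fold higher number from compound 2 to compound 3 (0.30 log units; that floor lies within the scatter) carried compound 3 to the limit. Compound 4 `N[C@H]1CC[C@H](Nc2c(C(=O)NCc3ccccc3)nc(Br)c3cccnc23)CC1` is reached from compound 3 through (benzyl in place of cyclohexyl on an amide-type nitrogen). This change runs back toward the amide-type nitrogen substituent of compound 2 and compound 1, both of which gave numbers below the limit, so a lower number than compound 3 is expected. The estimated step is an at least 1.6-fold lower number from compound 3 to compound 4 (0.22 log units; that floor lies within the scatter). Compound 4 is therefore expected to give 6000 nM in this assay, in a range from 2500 nM to 15000 nM.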

Compound 4, half-maximal inhibitory concentration: 7000 nM
Beside the measured number, compound 4's estimate is 1.2-fold (0.07 log units) below it; measured number inside the range.
By their numbers in this assay, from the lowest: compounds 1, 2 and 4 (each within the scatter of the next). At a limit, above all of these: compound 3.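

Compound 3 remains the only entry that marks a limit of the assay and not a number: the limit of > 10000 nM in this assay, at which 1 of the 4 values shown sits.

In this assay, from the compounds shown here alone, the change at the amide-type nitrogen reads as an at least 1.4-fold lower number from compound 3 to compound 4 (0.15 log units; that floor lies within the scatter), so benzyl gives a number where cyclohexyl gives none, but the true size of the step stays unknown. The plain benzyl also falls in with the substituted ones, with hydrogen in place of methoxy giving a 1.4-fold higher number from compound 2 to compound 4 (0.15 log units; within the scatter) and hydrogen in place of phenoxy giving a 1.8-fold higher number from compound 1 to compound 4 (0.24 log units; within the scatter), so neither substituent separates from hydrogen beyond the scatter.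

Open, going by these compounds, is whether a longer chain between the amide-type nitrogen and the phenyl ring, such as phenethyl, would shift the number beyond the scatter. Also open, on these data alone, is what a benzyl carrying an amine or a carboxylic acid would give.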